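The source may hold more compounds than are shown below. What is called first, only, known or untested is meant among the compounds shown, and "the series" means these compounds.

In a functional assay on Ramos cells (Homo sapiens) for antiproliferative activity, read by CCK-8 assay, with a stated time of 72 h, tested at 40 uM (a lower number here means less inhibition, a higher number more inhibition at the concentration tested (going by the name of the read-out)), compound 1 `CCOC(=O)c1sc(-c2cccc(NC(=O)c3ccccc3)c2)nc1Nc1ccc(N2CCN(C)CC2)cc1` gives 77.1%, the second highest of the three numbers measured. Compound 2 `CCOC(=O)c1sc(-c2cccc(NC(=O)c3cccc(F)c3)c2)nc1Nc1ccc(N2CCN(C)CC2)cc1` gives 85.2%, and the step of a number 8.1 percentage points higher from compound 1 to compound 2 (within the scatter) stays within the scatter. Compound 3 `CCOC(=O)c1sc(-c2cccc(NC(=O)c3ccc(Cl)cc3)c2)nc1Nc1ccc(N2CCN(C)CC2)cc1` gives 46.9%; the steps of a number 30.2 percentage points lower from compound 1 to compound 3 (beyond the scatter) and a number 38.3 percentage points lower from compound 2 to compound 3 (beyond the scatter) are both large. Compound 4 `CN1CCN(c2ccc(Nc3nc(-c4cccc(NC(=O)c5ccccc5)c4)sc3C(=O)O)cc2)CC1` differs from compound 1 by hydrogen in place of ethyl on an oxygen next to a carbonyl group. Every measured step changes the group on a carbonyl carbon and leaves the ethoxycarbonyl group untouched, so none of them bears on this change, and the measured compounds give no guide to its size or direction. Compound 4 is therefore estimated at 50%, with a wide range from 15% to 85%. The step expected is a number 27.1 percentage points lower from compound 1 to compound 4 (beyond the scatter), held with low confidence.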

Compound 4, a percentage reported as inhibition, at one concentration (the size of the read-out at that concentration, not a potency): 26.3%
Estimate against measurement, compound 4: 23.7 percentage points above; measured number inside the range.
By their numbers in this assay, from the lowest: compound 4; then compound 3; then compounds 1 and 2 (each within the scatter of the next).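

Going by these compounds alone, changing ethoxycarbonyl to carboxy is the first change tested at this place, and in this assay it gives a number 50.8 percentage points lower from compound 1 to compound 4 (beyond the scatter), a large step. Within the data shown here, the read-out at this concentration therefore depends on this position as well as on the group on the amide carbonyl, the only place varied among compounds 1 to 3. Nothing available explains this drop.

From the compounds shown here alone, it remains open whether a primary amide or a propyl ester at this place would keep the number of compound 1, and whether the same change from ethyl to hydrogen would lower compound 2 or compound 3 as far.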